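Series notes: the anilino substituent and growth inhibition

The source may hold more compounds than are shown below. What is called first, only, known or untested is meant among the compounds shown, and "the series" means these compounds.

Of the compounds shown here, three with a shared core have been measured in a functional assay on MV4-11 cells (Homo sapiens) for inhibition, with a stated time of 120 h, tested at 10 uM; on this read-out lower numbers stand for less inhibition and higher numbers for more inhibition at the one concentration tested (going by the name of the read-out). Compound 1 `Cc1n[nH]c2ccc(-c3nc4cnc(N5CCN(C)CC5)cn4c3Nc3ccccc3Cl)cc12` carries a 2-chlorophenyl on the ring nitrogen and gives 58.1%. Compound 2 `Cc1n[nH]c2ccc(-c3nc4cnc(N5CCN(C)CC5)cn4c3Nc3cccc(Cl)c3)cc12` carries a 3-chlorophenyl and gives 0%. Within the data shown here, compound 3 `Cc1n[nH]c2ccc(-c3nc4cnc(N5CCN(C)CC5)cn4c3Nc3ccccc3)cc12` carries a plain phenyl and in this assay gives 0%, level with compound 2 and together the lowest of the three numbers; the only compound standing apart is compound 1, with the step of a number 58.1 percentage points lower from compound 1 to compound 3 (beyond the scatter). The step of no change at the digits printed from compound 2 to compound 3 (within the scatter) shows that a chloro on the 3-chlorophenyl of compound 2 adds nothing measurable.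

Compound 4 `Cc1n[nH]c2ccc(-c3nc4cnc(N5CCN(C)CC5)cn4c3Nc3ccc(F)cc3Br)cc12` differs from compound 3 by 2-bromo-4-fluorophenyl in place of phenyl on a nitrogen on an aromatic ring. The step that bears on it is a number 58.1 percentage points lower from compound 1 to compound 3 (beyond the scatter), where removing the chloro of the 2-chlorophenyl cost everything; the 2-bromo-4-fluorophenyl of compound 4 restores a halogen at the position named in its group. Among the measured compounds shown here, a rise is therefore expected, of the order of a number 45 percentage points higher from compound 3 to compound 4 (beyond the scatter), though no bromo or fluoro analogue has been measured, so the range is wide. Compound 4 is estimated at 45%, between 5% and 80%.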

Compound 4, a percentage reported as inhibition, at one concentration (the size of the read-out at that concentration, not a potency): 82.4%
The estimate for compound 4 lay 37.4 percentage points below the measured number; the measured number lies above the stated range.
By their numbers in this assay, from the lowest: compounds 2 and 3 (each within the scatter of the next); then compound 1; then compound 4.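

In this assay, 2-bromo-4-fluorophenyl on the nitrogen gives a number 82.4 percentage points higher from compound 3 to compound 4 (beyond the scatter) and a number 82.4 percentage points higher from compound 2 to compound 4 (beyond the scatter), and it also exceeds the 2-chlorophenyl, with a number 24.3 percentage points higher from compound 1 to compound 4 (beyond the scatter), so the level reached by compound 1 is not the ceiling for this position. This change brings in bromine and fluorine together, so the step from compound 1 cannot be divided between the change of halogen and the added fluoro. No supporting data bear on why the number rises at this position.

Still open, as far as these compounds go, is how much of the gain would remain with the bromo or the fluoro alone on the phenyl. Also open, from the compounds shown here alone, is whether a halogen is needed at all, or whether a methyl, a methoxy or an amine on the phenyl ring would give a comparable read-out.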